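Compound 3: a new group on the oxygen of compound 2

A few compounds are considered here, and "the series" means these few. Any claim that something is new, unique, unknown or untested is made for them only; others in the source may bear on it.

Among the measured compounds shown here, in a functional assay on HeLa cells (Homo sapiens) for antiproliferative activity (a lower number here means a stronger inhibitor, a higher number a weaker inhibitor), compound 2 `CC(=O)O[C@@H]1/C=C(\C)CC[C@]2([C@@](C)(O)C(=O)SCc3oc(=O)oc3C)CC(=O)N([C@H](C)c3nc(cs3)/C=C/C=C/C1=O)[S+]2[O-]` gives 3.9 nM, the higher of the two numbers so far, and compound 1 `COCO[C@@H]1/C=C(\C)CC[C@]2([C@@](C)(O)C(=O)SCc3oc(=O)oc3C)CC(=O)N([C@H](C)c3nc(cs3)/C=C/C=C/C1=O)[S+]2[O-]` gives 0.17 nM. For the measured compounds named here, one measured step bears on the next change: a 23-fold higher number from compound 1 to compound 2 (1.36 log units; beyond the scatter), which is large and beyond the scatter, with acetyl in place of methoxymethyl on an oxygen on a saturated carbon.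

Compound 3 `COC1(O[C@@H]2/C=C(\C)CC[C@]3([C@@](C)(O)C(=O)SCc4oc(=O)oc4C)CC(=O)N([C@H](C)c4nc(cs4)/C=C/C=C/C2=O)[S+]3[O-])CCOCC1` differs from compound 2 at that same oxygen: 4-methoxyoxan-4-yl in place of acetyl on an oxygen on a saturated carbon. This places 4-methoxyoxan-4-yl in place of acetyl on an oxygen on a saturated carbon. Like the methoxymethyl of compound 1, the entering group has no carbonyl, so the measured step points towards recovery of a lower number in this assay. That reading rests on a single pair, and no group of this size has yet been measured here, so only part of the step may carry over. The expected change is a 7.8-fold lower number from compound 2 to compound 3 (0.89 log units; beyond the scatter), in the direction of a lower number. For compound 3 the estimated value is 0.5 nM, with an expected range of 0.1 nM to 3 nM.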

Compound 3, half-maximal inhibitory concentration: 1.4 nM
Estimate against measurement, compound 3: 2.8-fold (0.45 log units) below; the measured number falls inside the stated range.
By their numbers in this assay, from the lowest: compound 1; then compound 3; then compound 2.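

On the oxygen on a saturated carbon, a second group without a carbonyl now stands in place of acetyl, and in this assay the number again falls relative to the acetyl ester (a 2.8-fold lower number from compound 2 to compound 3 (0.44 log units; beyond the scatter)). The recovery is only partial, since 4-methoxyoxan-4-yl in place of methoxymethyl still leaves a clear gap (an 8.2-fold higher number from compound 1 to compound 3 (0.92 log units; beyond the scatter)), so lacking a carbonyl does not by itself bring a group to the level of compound 1, and this oxygen distinguishes between the two groups without a carbonyl. Nothing measured here gives a reason for these differences.

The three compounds do not separate the effect of the six-membered ring of 4-methoxyoxan-4-yl from that of its eight heavy atoms, and an open-chain group such as 2-methoxyethoxymethyl would bear directly on that question. They also leave open how a free hydroxyl on this oxygen would compare with the three groups, and so whether any of these groups improves on the unsubstituted oxygen at all.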